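Phenyl for Benzyl on the Amide Nitrogen of Compound 1

The source may hold more compounds than are shown below. What is called first, only, known or untested is meant among the compounds shown, and "the series" means these compounds.

- compound 1 `CCN(CC)c1nc(SCC(=O)NCc2ccccc2)c2ccccc2n1`: > 100000 nM
- compound 2 `CCN(CC)c1nc(NCC(=O)NCc2ccccc2)c2ccccc2n1`: > 100000 nM
- compound 3 `O=C(CNc1nc(N2CCc3ccccc3C2)nc2ccccc12)Nc1ccccc1`: 36600 nM

In an ADME assay on HEK-293T cells (Homo sapiens) for cytotoxicity, read by CCK-8 assay, with a stated time of 48 h (on this read-out higher numbers stand for lower toxicity in this test and lower numbers for higher toxicity in this test), compound 1 reaches only a limit of the test, > 100000 nM. Compound 2 likewise stops at a limit, > 100000 nM. Compound 3 gives a number, 36600 nM. Two of the three values therefore sit at the limit of > 100000 nM in this assay, at which 2 of the 3 values shown sit, and compound 1 stands at that limit without a number of its own. Compound 4 `CCN(CC)c1nc(SCC(=O)Nc2ccccc2)c2ccccc2n1` differs from compound 1 by phenyl in place of benzyl on an amide-type nitrogen. Going by the values given here, no step between measured compounds covers this change; compound 3 also bears a phenyl on an amide-type nitrogen but differs elsewhere, so it offers no direct step. The step from compound 1 to compound 4 is expected to be a number no higher from compound 1 to compound 4 (the limit leaves the size open), nothing beyond the scatter. Compound 4 is estimated at 100000 nM, between 30000 nM and 300000 nM.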

Compound 4, half-maximal cytotoxic concentration: > 100000 nM
Compound 4: only a limit was reported; the forecaster's own chance of this, stated with the estimate: 65%; the middle value lies on the limit itself.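

In this assay compound 4 reaches only a limit, > 100000 nM. Going by these compounds alone, compound 1 also stands at a limit, so no step between compound 1 and compound 4 can be read. The compounds shown leave open what size of change, if any, phenyl in place of benzyl brings.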